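The source may report more compounds than this note shows. Statements on the series, on what has been measured and on what is new or still open speak of the compounds shown alone.

Compound 1 `OC[C@]1(c2ccccc2)NC[C@H](O)[C@H]1O` gives 630 nM in an assay on isolated protein for inhibition of lysosomal alpha-glucosidase (Homo sapiens); on this read-out higher numbers stand for weaker inhibition and lower numbers for stronger inhibition. Compound 2 `OC[C@]1(c2cccc(F)c2)NC[C@H](O)[C@H]1O` gives 491000 nM in this assay.

Going by the values given here, of these two numbers compound 1 holds the lower one, and the only measured step is a 780-fold higher number from compound 1 to compound 2 (2.89 log units; beyond the scatter). Compound 3 `COc1ccc([C@@]2(CO)NC[C@H](O)[C@H]2O)cc1` differs from compound 1 by methoxy in place of hydrogen on an aromatic carbon. Among the compounds with values here, the one step that bears on a substituent placed on that aromatic ring, a 780-fold higher number from compound 1 to compound 2 (2.89 log units; beyond the scatter), was a large rise; a different substituent on the same ring is therefore expected to raise the number as well, though by an uncertain amount. Compound 3 is estimated at 50000 nM, with a range from 5000 nM to 500000 nM. The expected step is a 79-fold higher number from compound 1 to compound 3 (1.90 log units; beyond the scatter).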

Compound 3, half-maximal inhibitory concentration: 601000 nM
Estimate against measurement, compound 3: 12-fold (1.08 log units) below; the whole stated range lies below it.
By their numbers in this assay, from the lowest: compound 1; then compounds 2 and 3 (each within the scatter of the next).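

With methoxy on an aromatic carbon para to a group of 9 heavy atoms, this assay shows a 950-fold higher number from compound 1 to compound 3 (2.98 log units; beyond the scatter). The large rise seen with fluoro in compound 2 is therefore not confined to that group or its place on the ring, and among these three compounds only the unsubstituted ring of compound 1 holds a low number. Nothing measured here explains the rise. On these data alone, whether a methyl, a chlorine, an amine or a carboxylic acid on this ring would also raise the number remains open. So does how fluoro and methoxy would compare on the same ring carbon.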